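The source may hold more compounds than are shown below. What is called first, only, known or untested is meant among the compounds shown, and "the series" means these compounds.

Compound 1 `CC[C@H](C)[C@H](N)CN(C(=O)[C@@H]1C[C@H]1c1ncccn1)c1ccc(-c2ccccc2)cc1`: 130 nM
Compound 2 `CC[C@H](C)[C@H](N)CN(C(=O)[C@@H]1C[C@H]1c1nccs1)c1ccc(-c2ccccc2)cc1`: 210 nM
Compound 3 `CC(C)C[C@H](N)CN(C(=O)[C@@H]1C[C@H]1c1ccccc1)c1ccc(-c2cccs2)cc1`: 1500 nM

All numbers are from a functional assay for agonist activity at G protein-coupled receptor 88 (Homo sapiens), read by HTRF and cAMP accumulation; a higher number here means that more compound is needed for the effect, a lower number that less compound is needed. Compound 3 gives the highest of the three numbers, beyond the scatter of both others; compound 2 gives 210 nM and compound 1 gives 130 nM.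

Compound 4 `CC(C)C[C@H](N)CN(C(=O)[C@@H]1C[C@H]1c1ccccc1)c1ccc(-c2ccc(C#N)cc2)cc1` differs from compound 3 in one place: 4-cyanophenyl in place of thiophen-2-yl on an aromatic carbon. Among the compounds with values here, the only measured step, a 1.6-fold higher number from compound 1 to compound 2 (0.21 log units; within the scatter), concerns the group on the saturated ring carbon, not the place changed here, and lies within the scatter. Within the data shown here, compounds 1 and 2 carry a phenyl ring at the corresponding place and give lower numbers than compound 3, but they also differ from compound 3 in the cyclopropane substituent and the amine side chain, so no step isolates this change. A modest move toward lower numbers is expected, a 1.9-fold lower number from compound 3 to compound 4 (0.27 log units; within the scatter), with wide uncertainty. Compound 4 is therefore estimated at 800 nM, between 250 nM and 2500 nM.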

Compound 4, half-maximal effective concentration: 670 nM
Compound 4: middle estimate off by 1.2-fold (0.08 log units), on the high side; measured number inside the range.
By their numbers in this assay, from the lowest: compounds 1 and 2 (each within the scatter of the next); then compound 4; then compound 3.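

In this assay, within the data shown here, this is the only step that isolates the aromatic carbon para to a large group: 4-cyanophenyl in place of thiophen-2-yl gives a 2.2-fold lower number from compound 3 to compound 4 (0.35 log units; beyond the scatter) and is modest but beyond the scatter. The position therefore tolerates a swap from 5 to 8 heavy atoms, including a nitrile, with no rise in the number. No measured evidence accounts for the step.

As far as these compounds go, it remains open whether a carboxylic acid or an amine in place of the nitrile would shift the number. From the compounds shown here alone, it is also open whether the step carries over to compounds with a pyrimidin-2-yl or 1,3-thiazol-2-yl group.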